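This account rests on a few compounds, and the source may have more. Where it says the series, first, only, none or still open, it means among the compounds named here.

Compound 1, `O=C1C(=O)N(CC(CO)NCCCNc2ccnc3cc(Cl)ccc23)c2ccccc21`, gives 2% in an ADME assay on HCT-116 cells (Homo sapiens) for cytotoxicity, read by MTT assay, with a stated time of 48 h, tested at 0.2 uM; a higher number here means a stronger effect of the compound at the concentration tested, a lower number a weaker effect.
Compound 2, `O=C1C(=O)N(CC(CO)NCCNc2ccnc3cc(Cl)ccc23)c2ccc(Cl)cc21`, gives 0% in this assay.

Of these two numbers, compound 1 has the higher one, but the value of compound 2 lies within the usual scatter of it, so the two compounds cannot be told apart on this evidence. Both sit at the bottom of the scale, showing next to no effect at the concentration tested.

Compound 3, `O=C1C(=O)N(CC(CO)NCCCNc2ccnc3cc(Cl)ccc23)c2ccc(F)cc21`, is not yet measured. It differs from compound 1 by fluoro in place of hydrogen on an aromatic carbon, the fluorine entering on an aromatic carbon of a six-membered aromatic ring of carbon only within the shared core. Among the compounds with values here, no step between measured compounds exists to show what such a change does here. With both measured compounds near zero, the step expected in this assay is a number 1 percentage points higher from compound 1 to compound 3 (within the scatter), none beyond the scatter. Compound 3 is therefore expected to give about 3%, within a range from -8% to 15%.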

Compound 3, a percentage reported as inhibition, at one concentration (the size of the read-out at that concentration, not a potency): -2%
Compound 3: middle estimate off by 5 percentage points, on the high side; the measured number falls inside the stated range.
By their numbers in this assay, from the lowest: compounds 3, 2 and 1 (each within the scatter of the next).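

Fluoro in place of hydrogen on an aromatic carbon of the shared core brings a number 4 percentage points lower from compound 1 to compound 3 (within the scatter) in this assay. Within the data shown here, this is the first direct look at this position, and the swap produces no difference that can be told from the scatter. Compound 1 already sits at the bottom of the scale, however, so the step could reveal a gain in effect but hardly a loss, and nothing measured here offers an explanation for the result.

Going by these compounds, it remains open whether a larger group at this place, such as methoxy, trifluoromethyl or an amine, would lift the read-out clear of the scatter. It is also unknown whether compound 1 and compound 3 would separate at a higher concentration, where both might show a real effect.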